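Extending the alkyl chain of a threonine-derived sorbamide

The source may report more compounds than this note shows. Statements on the series, on what has been measured and on what is new or still open speak of the compounds shown alone.

Compound 2, `C/C=C/C=C/C(=O)N[C@H](C(=O)NCCCCCCCCCCCC)[C@@H](C)O`, gives 171000 nM in a functional assay on A-431 cells (Homo sapiens) for cytotoxicity, read by MTT assay, with a stated time of 48 h (on this read-out higher numbers stand for weaker inhibition and lower numbers for stronger inhibition), the highest of the two numbers recorded in this assay. Within the data shown here, its only neighbour is compound 1, `CCCCCCCCCCCCNC(=O)[C@@H](NC(=O)c1cc2ccccc2o1)[C@@H](C)O`, which in this assay gives 20000 nM; the step of an 8.6-fold higher number from compound 1 to compound 2 (0.93 log units; beyond the scatter) arises from penta-1,3-dien-1-yl in place of 1-benzofuran-2-yl on a carbonyl carbon.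

Compound 3, `C/C=C/C=C/C(=O)N[C@H](C(=O)NCCCCCCCCCCCCCCCCCC)[C@@H](C)O`, keeps the acyl group of compound 2 and alters only the other end of the molecule: hexyl in place of hydrogen on a saturated chain carbon, ten or more bonds along the chain from an amide-type nitrogen. Among the measured compounds shown here, no measured step concerns this part of the structure, since the single step recorded changes the acyl group rather than the saturated chain. For the measured compounds named here, the change from compound 2 to compound 3 therefore has no direct precedent in these data, and there is no basis for expecting a step beyond the scatter in either direction.

Compound 3 is accordingly expected to give about 150000 nM in this assay, with a plausible range from 50000 nM to 450000 nM, which means an expected step of a 1.1-fold lower number from compound 2 to compound 3 (0.06 log units; within the scatter).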

Compound 3, half-maximal inhibitory concentration: 187000 nM
Compound 3: the middle estimate sits 1.2-fold (0.10 log units) below what was measured; the range from low to high includes it.
By their numbers in this assay, from the lowest: compound 1; then compounds 2 and 3 (each within the scatter of the next).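

In this assay, among these compounds, hexyl in place of hydrogen on a saturated chain carbon, ten or more bonds along the chain from an amide-type nitrogen, gives a 1.1-fold higher number from compound 2 to compound 3 (0.04 log units; within the scatter), the first reading at this end of the molecule, and it leaves compound 2 and compound 3 indistinguishable in this assay. Among the compounds shown here, with the penta-1,3-dien-1-yl acyl group in place, this chain extension therefore has no effect that can be told from the scatter, whereas the only step beyond the scatter so far, an 8.6-fold higher number from compound 1 to compound 2 (0.93 log units; beyond the scatter), comes from the acyl group at the other end. Nothing measured alongside these numbers offers an explanation for the flat result.

As far as these compounds go, whether the same hexyl extension would also read within the scatter on the 1-benzofuran-2-yl acyl group of compound 1 remains open, since a single pair cannot show whether the two ends of the molecule act independently. Also open, from the compounds shown here alone, is whether a much shorter chain, or a chain ending in an amine or a carboxylic acid, would shift the number beyond the scatter at this position.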